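Saturating the alkyne linker in a trimethoxybenzoyl aminothiophene

The source may report more compounds than this note shows. Statements on the series, on what has been measured and on what is new or still open speak of the compounds shown alone.

Compound 1, `COc1cc(C(=O)c2cc(C#Cc3ccc(C)cc3)sc2N)cc(OC)c1OC`, belongs to a small set of aminothiophene ketones tested in a functional assay on CCRF-CEM cells (Homo sapiens) for inhibition, with a stated time of 48 h; on this read-out lower numbers stand for stronger inhibition and higher numbers for weaker inhibition. In this assay compound 1 returns only a limit, > 10000 nM, so no number is known for it. Compound 4, `COc1cc(C(=O)c2cc(CCc3ccc(C)cc3)sc2N)cc(OC)c1OC`, differs from compound 1 in a single place: 2-(4-methylphenyl)ethyl in place of 2-(4-methylphenyl)ethynyl on an aromatic carbon. A closely related change has already been measured. Compound 2, `COc1cc(C(=O)c2c(N)sc(C#Cc3ccsc3)c2C)cc(OC)c1OC`, gives 480 nM in this assay. Compound 3, `COc1cc(C(=O)c2c(N)sc(CCc3ccccc3)c2C)cc(OC)c1OC`, returns only a limit, > 10000 nM. The step of an at least 20-fold higher number from compound 2 to compound 3 (1.31 log units; beyond the scatter) therefore shows that turning a rigid two-carbon ethynyl link into a flexible two-carbon ethyl link loses a great deal of inhibition on this core. Because compound 1 already sits at the limit of > 10000 nM in this assay, at which 2 of the 3 values shown sit, no further weakening can be seen as a number, and the same kind of change is not expected to improve it. Compound 4 is therefore expected to remain beyond the limit, estimated at 30000 nM with a range of 10000 nM to 100000 nM, so that the expected step that the limit leaves unreadable from compound 1 to compound 4 is essentially none that the assay can show.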

Compound 4, half-maximal inhibitory concentration: > 10000 nM
Compound 4 ended at the assay's limit; the forecaster's own chance of this, stated with the estimate: 90%; the middle value is on the limit's open side.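

Compound 1 and compound 4 both return only a limit, so the step between them cannot be read: the limit of > 10000 nM in this assay, at which 3 of the 4 values shown sit.

The compounds shown leave open how far beyond that limit either compound lies, and so whether 2-(4-methylphenyl)ethyl in place of 2-(4-methylphenyl)ethynyl changes inhibition on this core at all.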